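N-methylation of the ureido nitrogen in compound 3

This account rests on a few compounds, and the source may have more. Where it says the series, first, only, none or still open, it means among the compounds named here.

Compound 3 `NC(=O)NC[C@@H]1CCCc2cc(S(=O)(=O)c3cccc(F)c3)ccc21` gives the lowest number of the three in an assay on isolated protein for displacement of a labelled ligand from 5-hydroxytryptamine receptor 6 (Homo sapiens) (on this read-out higher numbers stand for weaker inhibition and lower numbers for stronger inhibition), 0.2 nM; compound 1 `CNS(=O)(=O)NC[C@@H]1CCCc2cc(S(=O)(=O)c3cccc(F)c3)ccc21` gives 1 nM and compound 2 `O=C(NC[C@@H]1CCCc2cc(S(=O)(=O)c3cccc(F)c3)ccc21)c1ccc[nH]1` gives 5.01 nM. The steps of a 5.0-fold lower number from compound 1 to compound 3 (0.70 log units; beyond the scatter) and a 25-fold lower number from compound 2 to compound 3 (1.40 log units; beyond the scatter) both end at compound 3, while a 5.0-fold higher number from compound 1 to compound 2 (0.70 log units; beyond the scatter) links the other two. Compound 4 `CN(C[C@@H]1CCCc2cc(S(=O)(=O)c3cccc(F)c3)ccc21)C(N)=O` differs from compound 3 by methyl in place of hydrogen on an amide-type nitrogen. Among the compounds with values here, every measured step exchanges the whole group on the amine nitrogen; none adds a methyl to the amide-type nitrogen of the ureido group, so no step bears directly on this change and its direction is open. A small shift in this assay towards a higher number is expected, a 3.0-fold higher number from compound 3 to compound 4 (0.48 log units; beyond the scatter). Compound 4 is estimated at 0.6 nM in this assay, within 0.15 nM to 2.5 nM.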

Compound 4, inhibition constant: 39.8 nM
The estimate for compound 4 lay 66-fold (1.82 log units) below the measured number; the whole stated range lies below it.
By their numbers in this assay, from the lowest: compound 3; then compound 1; then compound 2; then compound 4.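

In this assay, adding one methyl to the amide-type nitrogen gives the largest step in the series, a 200-fold higher number from compound 3 to compound 4 (2.30 log units; beyond the scatter), so this position is far less forgiving than the earlier exchanges of the whole group suggested. The methylated compound also falls behind both compounds that keep the amide hydrogen, with a 40-fold higher number from compound 1 to compound 4 (1.60 log units; beyond the scatter) and a 7.9-fold higher number from compound 2 to compound 4 (0.90 log units; beyond the scatter). Nothing available explains this loss.

Still open, from the compounds shown here alone, is whether an ethyl group on this nitrogen behaves like methyl. Also open, going by these compounds, is whether methyl on the terminal amino group of the ureido unit, or on the same nitrogen in compound 1 or compound 2, carries a similar cost.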